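A side-chain swap awaiting its number

The source may hold more compounds than are shown below. What is called first, only, known or untested is meant among the compounds shown, and "the series" means these compounds.

Values measured so far in a functional assay on LNCaP cells (Homo sapiens) for antiproliferative activity; a higher number here means a weaker inhibitor, a lower number a stronger inhibitor:
compound 1 `CNC(=O)C[C@@H]1C[C@@H](c2ccc(Cl)c(Cl)c2)[C@H](NC(=O)c2cc(-c3c(Cl)cnn3C)c(Cl)o2)CN1` gives 40 nM
compound 2 `Cn1ncc(Cl)c1-c1cc(C(=O)N[C@@H]2CN[C@H](CCn3cncn3)C[C@H]2c2ccc(Cl)c(Cl)c2)oc1Cl` gives 60 nM

Going by the values given here, only these two numbers exist, and compound 2 stands within the scatter of its single neighbour. Among the compounds with values here, the one measured step is a 1.5-fold higher number from compound 1 to compound 2 (0.18 log units; within the scatter) and it brought (1H-1,2,4-triazol-1-yl)methyl in place of methylcarbamoyl.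

The next case is compound 3 `Cn1ncc(Cl)c1-c1cc(C(=O)N[C@@H]2CN[C@H](CCN3CCCCC3)C[C@H]2c2ccc(Cl)c(Cl)c2)oc1Cl` which differs from compound 2 in one group. It has piperidin-1-yl in place of 1H-1,2,4-triazol-1-yl on a saturated chain carbon, two bonds along the chain from a saturated ring carbon.

Within the data shown here, that single measured step is the only evidence on this side chain, and it did not leave the scatter. Neither measured compound carries piperidin-1-yl, so the data point in no direction. In this assay no shift beyond the scatter is therefore expected, though one small step is thin support. The expected change is modest, an estimated 1.2-fold higher number from compound 2 to compound 3 (0.07 log units; within the scatter) and nothing more. The value estimated for compound 3 is 70 nM (expected range 25 nM to 200 nM).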

Compound 3, half-maximal inhibitory concentration: 1780 nM
Compound 3: middle estimate off by 25-fold (1.41 log units), on the low side, and the stated range ends below it.
By their numbers in this assay, from the lowest: compounds 1 and 2 (each within the scatter of the next); then compound 3.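

The earlier pair hinted that the end of this side chain could change with little effect, but that does not hold for every group. In this assay, piperidin-1-yl in place of 1H-1,2,4-triazol-1-yl on the same chain gives a 30-fold higher number from compound 2 to compound 3 (1.47 log units; beyond the scatter), and (piperidin-1-yl)methyl in place of methylcarbamoyl gives a 45-fold higher number from compound 1 to compound 3 (1.65 log units; beyond the scatter), so compound 3 stands well apart from both neighbours and the position clearly responds to what sits at the chain end. One five-membered aromatic ring with 3 hetero atoms gives way here to one six-membered non-aromatic ring with 1 hetero atom, and no measurement shown says which part of that difference accounts for the loss.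

The compounds shown leave open whether ring size, aromatic character or the number of hetero atoms matters most; morpholin-4-yl, a six-membered non-aromatic ring with an added ring oxygen, and 1H-pyrazol-1-yl, a five-membered aromatic ring, would begin to pull these apart. Also open, going by these compounds, is how piperidin-1-yl would behave on a shorter or a longer chain.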